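The source may report more compounds than this note shows. Statements on the series, on what has been measured and on what is new or still open speak of the compounds shown alone.

Measured in a functional assay on LOX IMVI cells (Homo sapiens) for cytotoxicity, read by MTT assay, with a stated time of 24 h; on this read-out higher numbers stand for weaker inhibition and lower numbers for stronger inhibition:
- compound 1 `COc1cc(-c2nc(-c3ccccc3)[nH]c2-c2ccnc(NCCCNS(=O)(=O)c3ccccc3)n2)ccc1F`: 4520 nM
- compound 2 `COc1cc(-c2nc(-c3ccccc3)[nH]c2-c2ccnc(NCCCNS(=O)(=O)c3ccc(C)cc3)n2)ccc1F`: 2590 nM
- compound 3 `COc1cc(-c2nc(-c3ccccc3)[nH]c2-c2ccnc(NCCCNS(=O)(=O)c3ccc(Cl)cc3)n2)ccc1Cl`: 60900 nM

Compound 3 has the highest number of the three, beyond the scatter of both others. Compound 4 `COc1ccc(S(=O)(=O)NCCCNc2nccc(-c3[nH]c(-c4ccccc4)nc3-c3ccc(Cl)c(OC)c3)n2)cc1` has methoxy in place of chloro on an aromatic carbon, para to a large group: methoxy in place of chloro on an aromatic carbon. Among the compounds with values here, the only measured step on that ring is a 1.7-fold lower number from compound 1 to compound 2 (0.24 log units; within the scatter), for methyl in place of hydrogen. Compound 3 also differs from the other two at a second place on the shared core, and the data do not separate these two differences. A modest move to a lower number is therefore expected in this assay, with wide uncertainty. The expected change is a 2.4-fold lower number from compound 3 to compound 4 (0.39 log units; beyond the scatter). For compound 4 the estimate is 25000 nM, within a range of 6000 nM to 70000 nM.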

Compound 4, half-maximal inhibitory concentration: 1800 nM
Compound 4: middle estimate off by 14-fold (1.14 log units), on the high side; measured number below the stated range.
By their numbers in this assay, from the lowest: compounds 4, 2 and 1 (each within the scatter of the next, the first and the last beyond it); then compound 3.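

In this assay, the change from 4-chlorophenyl to 4-methoxyphenyl gives a 34-fold lower number from compound 3 to compound 4 (1.53 log units; beyond the scatter), a large step at this position, para to a large group. Compound 3 and compound 4 share the rest of the structure, so this step reads on the sulfonyl-bearing ring alone, and that ring's para substituent can move the number far more than the earlier methyl-for-hydrogen step did. No available evidence accounts for the size of this step. Open, from the compounds shown here alone, is how an amine or a carboxylic acid at this position would read, and whether the chloro-to-methoxy step holds with fluoro on the shared core.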